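Shortening the Chain at the Diene Carbon

The source may hold more compounds than are shown below. What is called first, only, known or untested is meant among the compounds shown, and "the series" means these compounds.

Compound 1, `CCCC/C(=C\C=C\C(=O)N[C@H](C)CCCc1cccnc1)c1ccc(OC)cc1`, gives 14 nM in an assay (Canis lupus familiaris) for binding affinity to platelet-activating factor receptor (Homo sapiens), read by radioligand binding; a lower number here means a stronger inhibitor, a higher number a weaker inhibitor.
Compound 2, `COc1ccc(/C(=C/C=C/C(=O)N[C@H](C)CCCc2cccnc2)C2CCCCC2)cc1`, gives 20 nM in this assay.

Compound 2 has the higher of the two numbers, but its nearest neighbour is compound 1, and the step of a 1.4-fold higher number from compound 1 to compound 2 (0.15 log units; within the scatter) lies within the scatter of repeated measurements. On these numbers, then, compound 1 and compound 2 cannot be told apart.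

Compound 3, `CCC/C(=C\C=C\C(=O)N[C@H](C)CCCc1cccnc1)c1ccc(OC)cc1`, has not yet been measured. It differs from compound 2 in one place: propyl in place of cyclohexyl on a double-bonded chain carbon bound to an aromatic carbon and a double-bonded chain carbon. Among the compounds with values here, the only measured step that bears on this position is a 1.4-fold higher number from compound 1 to compound 2 (0.15 log units; within the scatter), where a straight chain gave way to a ring at the same carbon without moving the number beyond the scatter. The change to compound 3 reverses that exchange and trims the chain further, so no step beyond the scatter is expected in this assay; the expected step is a 1.3-fold lower number from compound 2 to compound 3 (0.10 log units; within the scatter). Compound 3 is therefore estimated at 16 nM, with a likely range from 6 nM to 45 nM.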

Compound 3, half-maximal inhibitory concentration: 50 nM
Beside the measured number, compound 3's estimate is 3.1-fold (0.49 log units) below it; measured number above the stated range.
By their numbers in this assay, from the lowest: compounds 1 and 2 (each within the scatter of the next); then compound 3.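

In this assay, this position proves sensitive to the group it carries: exchanging cyclohexyl for propyl gives a 2.5-fold higher number from compound 2 to compound 3 (0.40 log units; beyond the scatter) and so lies beyond the scatter, whereas the exchange of butyl for cyclohexyl, a 1.4-fold higher number from compound 1 to compound 2 (0.15 log units; within the scatter), did not. The straight chains also differ from each other, as the change of hydrogen in place of methyl on a saturated chain carbon, three bonds along the chain from a double-bonded chain carbon, gives a 3.6-fold higher number from compound 1 to compound 3 (0.55 log units; beyond the scatter) and shows that this one small trim is enough to move the number beyond the scatter. Among these three compounds, the butyl and cyclohexyl compounds cannot be told apart and only the propyl compound stands apart, and no measurement here explains that difference.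

The compounds shown leave open whether a longer chain such as pentyl or hexyl, or a smaller ring such as cyclopentyl, would keep the number close to those of compound 1 and compound 2. They also leave open how an amine or a carboxylic acid at the end of the chain on this carbon would fare.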